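This account rests on a few compounds, and the source may have more. Where it says the series, first, only, none or still open, it means among the compounds named here.

Measured so far in a functional assay on a cell-free system (plasma, Oryctolagus cuniculus) for inhibition, with stated times of 5 min, 1 min and 6 min; a lower number here means a stronger inhibitor, a higher number a weaker inhibitor:
compound 1, `C=CCOn1c(-c2cccc(C#N)c2)nc(C)c1C(=O)OCC`, gives 5860 nM.
compound 2, `CCOCCOn1c(-c2cccc(C#N)c2)nc(C)c1C(=O)OCC`, gives 6250 nM.
compound 3, `CCOC(=O)c1c(C)nc(-c2cccc(C#N)c2)n1OCc1ccccc1F`, gives 8990 nM.

Compound 3 stands with a 1.5-fold higher number from compound 1 to compound 3 (0.19 log units; within the scatter) and a 1.4-fold higher number from compound 2 to compound 3 (0.16 log units; within the scatter); the three numbers sit together, none separated from another beyond the scatter.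

Compound 4 is `CCOC(=O)c1c(C)nc(-c2cccc(C#N)c2)n1OCc1ccc([N+](=O)[O-])cc1`. The change from compound 3 is 4-nitrophenyl in place of 2-fluorophenyl on a saturated chain carbon bound to an oxygen on an aromatic ring.

For the measured compounds named here, the steps that bear on this are the three already made at the same place: a 1.1-fold higher number from compound 1 to compound 2 (0.03 log units; within the scatter), a 1.5-fold higher number from compound 1 to compound 3 (0.19 log units; within the scatter) and a 1.4-fold higher number from compound 2 to compound 3 (0.16 log units; within the scatter). Each swap on the saturated chain carbon bound to an oxygen on an aromatic ring has left the number where it was, so no step beyond the scatter is expected in this assay here either, in either direction. The estimated step is a 1.1-fold lower number from compound 3 to compound 4 (0.02 log units; within the scatter). Compound 4 is accordingly expected to give 8500 nM, with a range from 4000 nM to 18000 nM.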

Compound 4, half-maximal inhibitory concentration: 8750 nM
Compound 4: the middle estimate sits 1.0-fold (0.01 log units) below what was measured, within the range that was stated.
By their numbers in this assay, from the lowest: compounds 1, 2, 4 and 3 (each within the scatter of the next).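

In this assay, 4-nitrophenyl on the saturated chain carbon bound to an oxygen on an aromatic ring gives no step beyond the scatter against 2-fluorophenyl (a 1.0-fold lower number from compound 3 to compound 4 (0.01 log units; within the scatter)), ethoxymethyl (a 1.4-fold higher number from compound 2 to compound 4 (0.15 log units; within the scatter)) or vinyl (a 1.5-fold higher number from compound 1 to compound 4 (0.17 log units; within the scatter)). All four groups therefore sit within the scatter of one another at this place. No measurement shown bears on why the number stays flat. From the compounds shown here alone, whether an amine or a carboxylic acid at this place would move the number stays open, as does the effect of changes elsewhere on the shared core.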